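Allylamino in Place of Methylamino on Compound 1

The source may hold more compounds than are shown below. What is called first, only, known or untested is meant among the compounds shown, and "the series" means these compounds.

Measured so far:
Compound 1 `CNc1nc(NCc2ccc(C(=O)Nc3ccc(F)cc3)cc2)c2ccccc2n1` gives 4100 nM in a functional assay on SW480 cells (Homo sapiens) for inhibition, read by luminescence and resazurin assay, with a stated time of 3 days; on this read-out lower numbers stand for stronger inhibition and higher numbers for weaker inhibition.
Compound 2 `CNc1nc(NCc2ccc(NC(=O)c3ccc(F)cc3)cc2)c2ccccc2n1` gives 2000 nM in this assay.
Compound 3 `Cc1ccc2nc(N(C)C)nc(NCc3ccc(C(=O)N4CCC(C(=O)NCc5ccc(F)cc5)CC4)cc3)c2c1` gives 5600 nM in this assay.

For the measured compounds named here, compound 1 stands among the higher numbers; its gap to compound 3 lies within the scatter, whereas the only single-place step, a 2.1-fold lower number from compound 1 to compound 2 (0.31 log units; beyond the scatter), lies beyond it and concerns the amide linkage, not the amine.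

Compound 4 `C=CCNc1nc(NCc2ccc(C(=O)Nc3ccc(F)cc3)cc2)c2ccccc2n1` differs from compound 1 by vinyl in place of hydrogen on a saturated chain carbon bound to a nitrogen on an aromatic ring; the same difference, cut one bond further out, reads methylamino to allylamino. Going by the values given here, no measured step touches this position, so nothing in the data points either way. The expected step is therefore no change at the digits printed from compound 1 to compound 4 (within the scatter), none beyond the scatter. Compound 4 is expected to give 4100 nM, with a range from 1500 nM to 11000 nM.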

Compound 4, half-maximal inhibitory concentration: 11000 nM
For compound 4 the middle estimate is 2.7-fold (0.43 log units) below the measured one; the range from low to high includes it.
By their numbers in this assay, from the lowest: compound 2; then compounds 1, 3 and 4 (each within the scatter of the next, the first and the last beyond it).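

In this assay, the group on this nitrogen is shown for the first time to affect the read-out: allylamino in place of methylamino gives a 2.7-fold higher number from compound 1 to compound 4 (0.43 log units; beyond the scatter), a modest step in the weaker direction. This single pair shows that added vinyl is not tolerated without change at this position, and nothing shown here explains the step.

From the compounds shown here alone, it remains open whether the step goes with the double bond or with the longer chain, which a propylamino group could separate. Going by these compounds, the effect of allylamino on the reversed amide of compound 2 also remains open.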